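This account rests on a few compounds, and the source may have more. Where it says the series, first, only, none or still open, it means among the compounds named here.

compound 1 `CNC(=O)Nc1nccc(COc2cc(OC)c3nc(N[C@H]4CCCC[C@@H]4O)sc3c2)n1`: 23 mL/min/kg
compound 2 `COc1cc(OCc2ccnc(Nc3ccn(C)n3)n2)cc2sc(N[C@H]3CCCC[C@@H]3O)nc12`: 17 mL/min/kg
compound 3 `COc1cc(OCc2ccnc(Nc3cn[nH]c3)n2)cc2sc(N[C@H]3CCCC[C@@H]3O)nc12`: 32 mL/min/kg

All three values come from an ADME assay on microsomes from liver (Homo sapiens) for pharmacokinetics, read by LC-MS, using NADPH, with a stated time of 45 min, tested at 1 uM; a lower number here means slower removal, a higher number faster removal of the compound. Compound 3 stands within the scatter of the other two, with measured steps of a 1.4-fold higher number from compound 1 to compound 3 (0.14 log units; within the scatter) and a 1.9-fold higher number from compound 2 to compound 3 (0.27 log units; within the scatter). Compound 4 `COc1cc(OCc2ccnc(Nc3cnoc3)n2)cc2sc(N[C@H]3CCCC[C@@H]3O)nc12` carries 1,2-oxazol-4-yl in place of 1H-pyrazol-4-yl on a nitrogen on an aromatic ring. Within the data shown here, no measured compound holds this group, so the evidence is indirect. Among the measured compounds shown here, the steps that bear on the change are those made at the same place: the two already given, and a 1.4-fold lower number from compound 1 to compound 2 (0.13 log units; within the scatter). None of the three leaves the scatter. With a 1.9-fold higher number from compound 2 to compound 3 (0.27 log units; within the scatter) as the step between the two pyrazole compounds, no step beyond the scatter is expected in this assay, and no clear direction can be drawn. The expected step is a 1.1-fold lower number from compound 3 to compound 4 (0.06 log units; within the scatter). For compound 4 the estimated value is 28 mL/min/kg, with an expected range from 14 mL/min/kg to 55 mL/min/kg.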

Compound 4, clearance: 61 mL/min/kg
For compound 4 the middle estimate is 2.2-fold (0.34 log units) below the measured one; measured number above the stated range.
By their numbers in this assay, from the lowest: compounds 2, 1, 3 and 4 (each within the scatter of the next, the first and the last beyond it).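

Among these compounds, with compound 4, the place on a nitrogen on an aromatic ring gives the first steps beyond the scatter in this assay, namely a 3.6-fold higher number from compound 2 to compound 4 (0.55 log units; beyond the scatter) and a 2.7-fold higher number from compound 1 to compound 4 (0.42 log units; beyond the scatter). The direct exchange of 1H-pyrazol-4-yl for 1,2-oxazol-4-yl is a 1.9-fold higher number from compound 3 to compound 4 (0.28 log units; within the scatter), so this exchange alone does not separate the two rings, and compound 4 stands apart only from compound 1 and compound 2. Nothing shown here accounts for the result.

The compounds shown leave open whether a 1,2-oxazol-4-yl ring bearing a methyl group on this nitrogen would stay near compound 4 or fall back towards compound 2. They also leave open how a six-membered pyridinyl ring at the same place would read.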